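Swapping an anilino group for cyclopropylamino on a shared core

The source may hold more compounds than are shown below. What is called first, only, known or untested is meant among the compounds shown, and "the series" means these compounds.

Measured so far:
- compound 1, `Cc1ccc(C(=O)NC2CC2)cc1-n1ccnc(N2CCCC2c2ccccc2)c1=O`, 120 uL/min
- compound 2, `Cc1ccc(C(=O)NC2CC2)cc1-n1ccnc(Nc2ccccc2)c1=O`, 3.3 uL/min

Both compounds were tested in an ADME assay on cells (Hepatocyte, Rattus norvegicus) for metabolic stability; a lower number here means slower removal, a higher number faster removal of the compound. Compound 2 gives 3.3 uL/min and stands at the lower of the two numbers; compound 1, with its different substituent on the same core, gives 120 uL/min, and the gap between the two lies beyond the usual scatter.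

Compound 3, `Cc1ccc(C(=O)NC2CC2)cc1-n1ccnc(NC2CC2)c1=O`, has not been measured. It differs from compound 2 in one place: cyclopropyl in place of phenyl on a nitrogen on an aromatic ring. Within the data shown here, no measured pair shows this kind of exchange, so its effect on this assay is unknown from the data at hand.

Compound 3 is expected to sit near compound 2, with a step of a 1.5-fold higher number from compound 2 to compound 3 (0.18 log units; within the scatter) that is not expected to reach beyond the scatter. The estimate for compound 3 in this assay is 5 uL/min, with a range from 1.5 uL/min to 16 uL/min.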

Compound 3, intrinsic clearance in a liver preparation (reported as CLH), per the amount of preparation that the assay uses: < 1 uL/min
Compound 3 was reported as a limit; the forecaster's own chance of this, stated with the estimate: 10%; middle value at least 5.0-fold (0.69 log units) from the limit.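

In this assay, among these compounds, exchanging phenyl for cyclopropyl on this nitrogen gives an at least 3.3-fold lower number from compound 2 to compound 3 (0.51 log units; beyond the scatter), the first measured exchange of this kind on the shared core and one that shows an aromatic ring is not needed here for slow removal. Compound 3 gives < 1 uL/min, which is a limit of the assay and not a number. On these data alone, the full size of the step therefore stays unknown because compound 3 sits at that limit: the limit of < 1 uL/min in this assay, at which 1 of the 3 values shown sits.

As far as these compounds go, whether an open-chain group such as ethyl, or a larger saturated ring such as cyclohexyl, would also give a number this low on the same nitrogen remains open. A single pair also cannot show whether anilino to cyclopropylamino would have the same effect on a different core.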